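The source may hold more compounds than are shown below. What is called first, only, known or untested is meant among the compounds shown, and "the series" means these compounds.

Measured compounds:
compound 1, `COC(=O)/C=C/c1ccc2c(c1)C(=O)C(=O)N2Cc1ccc2ccccc2c1`: 100 nM in a functional assay on HT-29 cells (Homo sapiens) for cytotoxicity, read by MTT assay, with a stated time of 48 h; a higher number here means a weaker inhibitor, a lower number a stronger inhibitor
compound 2, `COC(=O)/C=C/c1ccc2c(c1)C(=O)C(=O)N2Cc1ccc(OC)cc1`: 30 nM in this assay
compound 3, `COC(=O)/C=C/c1ccc2c(c1)C(=O)C(=O)N2Cc1cc(C)cc(C)c1`: 70 nM in this assay

Compound 3 holds the second highest of the three numbers in this assay. Its nearest neighbour is compound 1, whose value sits within the scatter of that of compound 3; compound 2 is the furthest away, separated by a 2.3-fold higher number from compound 2 to compound 3 (0.37 log units; beyond the scatter).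

Compound 4, `COC(=O)/C=C/c1ccc2c(c1)C(=O)C(=O)N2Cc1ccc(C#N)cc1`, has not yet been measured in this assay. It differs from compound 3 at one place: 4-cyanophenyl in place of 3,5-dimethylphenyl on a saturated chain carbon bound to an amide-type nitrogen in a ring

For the measured compounds named here, the only measured step at this position is a 2.3-fold higher number from compound 2 to compound 3 (0.37 log units; beyond the scatter), a modest change. Going by the values given here, no measured compound carries a nitrile, so the new group itself is untested. Because compound 2 gives 30 nM with a group of the same kind of ring at the same place, a return toward that lower number seems plausible, though the step from compound 3 to compound 4 is expected to be small, near the edge of the scatter: a 1.4-fold lower number from compound 3 to compound 4 (0.15 log units; within the scatter). Compound 4 is therefore expected to give about 50 nM in this assay, with a range from 20 nM to 150 nM.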

Compound 4, half-maximal inhibitory concentration: 50 nM
Compound 4: the middle estimate sits on the measured number at the digits printed; the measured number falls inside the stated range.
By their numbers in this assay, from the lowest: compounds 2, 4, 3 and 1 (each within the scatter of the next, the first and the last beyond it).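

For the compounds shown here, the step of a 1.4-fold lower number from compound 3 to compound 4 (0.15 log units; within the scatter) and the step of a 1.7-fold higher number from compound 2 to compound 4 (0.22 log units; within the scatter) both lie within the scatter in this assay, so the nitrile is the first group at this position that cannot be told apart from either neighbouring aromatic group. On a saturated chain carbon bound to an amide-type nitrogen in a ring, 4-cyanophenyl therefore sits with 3,5-dimethylphenyl and 4-methoxyphenyl, and the step of a 2.3-fold higher number from compound 2 to compound 3 (0.37 log units; beyond the scatter) remains the only one here beyond the scatter. No supporting measurement bears on why these values fall as they do.

The compounds shown leave open how an amine or a carboxylic acid in place of the nitrile would read in this assay. As far as these compounds go, a longer chain in place of the saturated chain carbon is equally open.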